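A few compounds are considered here, and "the series" means these few. Any claim that something is new, unique, unknown or untested is made for them only; others in the source may bear on it.

Working notes on the series. All compounds share one core bearing a phenyl group and a carboxylic acid or amide. Compound 1 `CC(C)=CCCC1=CC[C@H](C(=O)Nc2ccc(O)cc2)[C@@H](c2ccccc2)C1` carries the amide to 4-hydroxyphenyl. In an assay on isolated protein for inhibition of Apoptosis regulator Bcl-2 (Homo sapiens), read by fluorescence polarization, with stated times of 5 min and 10 min (on this read-out lower numbers stand for stronger inhibition and higher numbers for weaker inhibition), compound 1 gives > 23000 nM, which is a limit of the assay and not a number. Compound 2 `CC1(C)CCCC2=C1C[C@H](C(=O)O)[C@@H](c1ccccc1)C2`, the free acid, gives in this assay > 23000 nM, again a limit. Compound 3 `CC(C)=CCCC1=CC[C@@H](C(=O)Nc2ccc(O)cc2)[C@H](c2ccccc2)C1` is the mirror image of compound 1. In this assay compound 3 gives > 23000 nM, also a limit. The step that the two limits leave unreadable from compound 1 to compound 3 cannot be read because the limit of > 23000 nM in this assay, at which 3 of the 3 values shown sit, sits on both ends, even though the fact that compounds 1 and 3 differ only in the configuration as drawn makes it a pure configuration change.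

Compound 4 `CC(C)=CCCC1=CC[C@H](C(=O)NO)[C@@H](c2ccccc2)C1` differs from compound 1 by hydroxy in place of 4-hydroxyphenyl on an amide-type nitrogen. Among the measured compounds shown here, no measured step bears on this change in a readable way, and compound 1 itself stands only at the limit, so no size or direction of step beyond the scatter can be derived. Compound 4 is therefore expected to stay near the limit, with an estimate of 30000 nM (range 8000 nM to 100000 nM) and an expected step that the limit leaves unreadable from compound 1 to compound 4, which is nominal only.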

Compound 4, inhibition constant: 600 nM
Beside the measured number, compound 4's estimate is 50-fold (1.70 log units) above it, and the stated range ends above it.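

Hydroxy in place of 4-hydroxyphenyl on an amide-type nitrogen gives an at least 38-fold lower number from compound 1 to compound 4 (1.58 log units; beyond the scatter), the only readable step in the series, so this substituent on the amide decides whether the read-out leaves the limit. Compound 1 gives > 23000 nM in this assay, which is a limit of the assay and not a number, so the size of this step is a minimum. Compound 4 is the only compound shown with a number rather than a limit: the limit of > 23000 nM in this assay, at which 3 of the 4 values shown sit.

The compounds shown do not tell whether the step belongs to the entering hydroxy or to the loss of 4-hydroxyphenyl, which methoxy or a plain amino group on the same nitrogen could help to separate. Going by these compounds, the other steps cannot be read, so any role of configuration stays open, including for the mirror image of compound 4.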